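Swapping Two Methoxy Groups for Two Chlorines

This account rests on a few compounds, and the source may have more. Where it says the series, first, only, none or still open, it means among the compounds named here.

In a functional assay on U-87MG ATCC cells for antiproliferative activity against U-87 MG (Homo sapiens), read by MTT assay, with a stated time of 48 h, tested at 50 uM (on this read-out lower numbers stand for a stronger effect and higher numbers for a weaker effect at the one concentration tested), compound 1 `COc1ccc(-c2nc(C)c(C(=O)CSc3nc(-c4ccc(OC)c(OC)c4)c(C#N)c(=O)[nH]3)s2)cc1` gives 22.2%, the second highest of three numbers. Compound 2 `COc1ccc(-c2nc(SCC(=O)c3sc(-c4ccccc4)nc3C)[nH]c(=O)c2C#N)cc1OC` gives 21.4% in this assay, and compound 3 `COc1ccc(-c2nc(SCC(=O)c3sc(-c4ccc(Cl)cc4)nc3C)[nH]c(=O)c2C#N)cc1OC` gives 59.8%. Compound 4 `COc1ccc(-c2nc(C)c(C(=O)CSc3nc(-c4ccc(Cl)c(Cl)c4)c(C#N)c(=O)[nH]3)s2)cc1` differs from compound 1 by 3,4-dichlorophenyl in place of 3,4-dimethoxyphenyl on an aromatic carbon, on an aromatic carbon of a six-membered aromatic ring with 2 nitrogen. The measured steps that bear on this are a number 37.6 percentage points higher from compound 1 to compound 3 (beyond the scatter) and a number 38.4 percentage points higher from compound 2 to compound 3 (beyond the scatter), while a number 0.8 percentage points lower from compound 1 to compound 2 (within the scatter) shows methoxy and hydrogen giving alike numbers. Both chloro steps raised the number by a large amount. A rise well beyond the scatter is expected for the double chloro change as well. For compound 4 the expected value is 50%, with a range from 28% to 72%. This means an expected step of a number 27.8 percentage points higher from compound 1 to compound 4 (beyond the scatter).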

Compound 4, a percentage reported as activity, at one concentration (the size of the read-out at that concentration, not a potency): 78.4%
For compound 4 the middle estimate is 28.4 percentage points below the measured one; the whole stated range lies below it.
By their numbers in this assay, from the lowest: compounds 2 and 1 (each within the scatter of the next); then compound 3; then compound 4.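

In this assay, replacing 3,4-dimethoxyphenyl with 3,4-dichlorophenyl gives a number 56.2 percentage points higher from compound 1 to compound 4 (beyond the scatter) on the core of compound 1. For the compounds shown here, the earlier steps all changed the other phenyl ring, so this is the first sign that the group on the ring with 2 nitrogen also matters strongly for this read-out. Nothing measured here explains the rise.

Still open, as far as these compounds go, is whether a single chlorine on this phenyl would give the same large rise, or whether both are needed. From the compounds shown here alone, how an amine or a carboxylic acid would read at this position also remains unknown.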